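Swapping the thiophene arm for an aminothiazole arm

A few compounds are considered here, and "the series" means these few. Any claim that something is new, unique, unknown or untested is made for them only; others in the source may bear on it.

Measured so far in an assay for inhibition of Tryptophan 2,3-dioxygenase (Homo sapiens), with a stated time of 1 h, tested at 10 uM; on this read-out higher numbers stand for more inhibition at the one concentration tested (going by the name of the read-out) and lower numbers for less inhibition:
compound 1, `N#Cc1ccc(CNc2cc(Br)cc3[nH]ncc23)cc1`, gives 73%
compound 2, `Cc1cc(O)ccc1CNc1cc(Br)cc2[nH]ncc12`, gives 19%
compound 3, `Brc1cc(NCc2cccs2)c2cn[nH]c2c1`, gives 53%

Compound 3 stands second of the three. Compound 1 lies beyond the scatter above it, and compound 2 lies beyond the scatter below it, so the three numbers spread clearly.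

Compound 4, `Nc1nc(CNc2cc(Br)cc3[nH]ncc23)cs1`, is the next compound: 2-amino-1,3-thiazol-4-yl in place of thiophen-2-yl on a saturated chain carbon bound to a nitrogen on an aromatic ring. Going by the values given here, no step between measured compounds tells how this kind of swap behaves, and the two flanking compounds show that the arm can move the number either way. For compound 4 the step of a number 5 percentage points lower from compound 3 to compound 4 (within the scatter) is expected to stay within the scatter. Compound 4 is therefore estimated at 48% in this assay, between 20% and 75%.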

Compound 4, a percentage reported as inhibition, at one concentration (the size of the read-out at that concentration, not a potency): 73%
Beside the measured number, compound 4's estimate is 25 percentage points below it, and the stated range covers the measured number.
By their numbers in this assay, from the lowest: compound 2; then compound 3; then compounds 1 and 4 (each within the scatter of the next).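

Going by these compounds alone, the step at this position is the first to be read directly: in this assay, putting 2-amino-1,3-thiazol-4-yl in place of thiophen-2-yl gives a number 20 percentage points higher from compound 3 to compound 4 (beyond the scatter). A five-membered aromatic ring with 2 hetero atoms, carrying an amino group, is therefore accepted on this saturated chain carbon, and the change raises the number beyond the scatter. No evidence here says what lies behind this rise. The ring nitrogen and the amino group enter together, so the compounds shown leave open which of them matters. A thiazol-4-yl arm without the amine, or one with a methylamino group, would help separate the two.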